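A mirror-image step in a small series

A few compounds are considered here, and "the series" means these few. Any claim that something is new, unique, unknown or untested is made for them only; others in the source may bear on it.

In a functional assay on A549 cells (Homo sapiens) for inhibition, read by MTT assay, with a stated time of 72 h (on this read-out higher numbers stand for weaker inhibition and lower numbers for stronger inhibition), compound 1 `CC1=NN(c2ccccc2)C(=O)[C@@]12C(=O)C=CC[C@H]2c1ccc(C)cc1` gives 6090 nM, compound 2 `CC1=NN(c2ccccc2)C(=O)[C@@]12C(=O)C=CC[C@H]2c1ccccc1` gives 3770 nM and compound 3 `CC1=NN(c2ccc(C)cc2)C(=O)[C@@]12C(=O)C=CC[C@H]2c1ccc(C)cc1` gives 6790 nM. Compound 3 lies within the scatter of both other compounds, so the numbers do not set it apart from either.

Compound 4 `CC1=NN(c2ccc(C)cc2)C(=O)[C@]12C(=O)C=CC[C@@H]2c1ccc(C)cc1` has not yet been measured. The structural change is the two compounds have the same atoms and bonds and differ only in configuration as drawn: 2 of 2 stereo elements differ (all stereocentres are inverted: mirror images); a stereocentre at a saturated ring carbon is drawn R in compound 3 and S in compound 4; a stereocentre at a saturated ring carbon is drawn S in compound 3 and R in compound 4; the two compounds are mirror images, with the same atoms and bonds.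

Two measured steps are available: a 1.6-fold lower number from compound 1 to compound 2 (0.21 log units; within the scatter) and a 1.1-fold higher number from compound 1 to compound 3 (0.05 log units; within the scatter). Both are small and within the scatter, but both concern a methyl on an aromatic carbon, and neither inverts a stereocentre. Going by the values given here, the series therefore holds no measured mirror-image pair, and the size of this step is not directly known. No shift beyond the scatter in this assay is expected, though with wide uncertainty in either direction. The expected step is a 1.1-fold lower number from compound 3 to compound 4 (0.05 log units; within the scatter). Compound 4 is estimated at 6000 nM, with an expected range of 2500 nM to 15000 nM.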

Compound 4, half-maximal inhibitory concentration: 54300 nM
Compound 4: middle estimate off by 9.1-fold (0.96 log units), on the low side; the whole stated range lies below it.
By their numbers in this assay, from the lowest: compounds 2, 1 and 3 (each within the scatter of the next); then compound 4.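

In this assay the series now holds a step beyond the scatter, an 8.0-fold higher number from compound 3 to compound 4 (0.90 log units; beyond the scatter), whereas the methyl changes on the aromatic carbons, a 1.6-fold lower number from compound 1 to compound 2 (0.21 log units; within the scatter) and a 1.1-fold higher number from compound 1 to compound 3 (0.05 log units; within the scatter), stay within it. The configuration at these two stereocentres therefore matters in this series more than any methyl change shown so far. The gap can be assigned to configuration alone because nothing else separates the pair: the fact that compounds 3 and 4 differ only in the configuration as drawn.

From the compounds shown here alone, both stereocentres are inverted together, so the share of each one in the step stays open, and a compound inverted at a single stereocentre would be needed to separate them. Also open, going by these compounds, is how a carboxylic acid or an amine in place of methyl on an aromatic carbon would read in this assay, and whether such a change would alter the size of the mirror-image step.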